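Extending the ethyl chain in a dose-response series

The source may hold more compounds than are shown below. What is called first, only, known or untested is meant among the compounds shown, and "the series" means these compounds.

Of the compounds shown here, two have been measured in a functional assay on the whole organism with Rattus norvegicus as the target; a lower number here means that less compound is needed, a higher number that more compound is needed for the effect. Compound 1 `CCCCc1c(OC)nc2nc(C(=O)c3ccccc3)cn2c1CC` gives 10 mg/kg, while compound 2 `CCc1cc(OC)nc2nc(C(=O)c3ccccc3)cn12` gives 2 mg/kg. Among the measured compounds shown here, the single step between them, a 5.0-fold lower number from compound 1 to compound 2 (0.70 log units; beyond the scatter), shows that losing the butyl group lowered the dose needed. For the measured compounds named here, compound 2 therefore stands as the lower of the two numbers measured so far.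

Compound 3 `CCCCc1cc(OC)nc2nc(C(=O)c3ccccc3)cn12` has not yet been measured. Its difference from compound 2 is ethyl in place of hydrogen on a saturated chain carbon, two bonds along the chain from an aromatic carbon, so the ethyl of compound 2 becomes a butyl. Going by the values given here, only one measured step bears on this, and it concerns removing a butyl rather than building one, but its direction suggests that a longer chain tends to require more compound. A modest rise in the dose is therefore expected, not a large one. Compound 3 is estimated at 4 mg/kg, within a range of 1.5 mg/kg to 12 mg/kg, which means an expected step of a 2.0-fold higher number from compound 2 to compound 3 (0.30 log units; within the scatter).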

Compound 3, minimum effective dose: 10 mg/kg
Compound 3: the middle estimate sits 2.5-fold (0.40 log units) below what was measured; measured number inside the range.
By their numbers in this assay, from the lowest: compound 2; then compounds 1 and 3 (each within the scatter of the next).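

Lengthening the ethyl of compound 2 to the butyl of compound 3 gives a 5.0-fold higher number from compound 2 to compound 3 (0.70 log units; beyond the scatter) in this assay, the first measured evidence that this chain itself affects the dose, since the earlier step concerned only a butyl on an aromatic carbon. Ethyl in place of hydrogen on a saturated chain carbon, two bonds along the chain from an aromatic carbon, therefore carries a cost beyond the scatter, and the shorter ethyl chain is the better of the two tested here. Nothing available accounts for this rise.

The compounds shown leave open whether the dose climbs steadily with chain length, as a methyl or propyl chain at this place would show. They also leave open how a chain ending in an amine or a carboxylic acid would behave.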